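The source may hold more compounds than are shown below. What is called first, only, known or untested is meant among the compounds shown, and "the series" means these compounds.

Measured compounds:
- compound 1 `COc1ccc(C(=O)C2Sc3nnc(-c4cc(OC)c(OC)c(OC)c4)n3NC2c2ccco2)cc1` gives > 100000 nM in a functional assay on A549 cells (Homo sapiens) for cytotoxicity, read by MTT assay, with a stated time of 48 h; a lower number here means a stronger inhibitor, a higher number a weaker inhibitor; this value is a limit of the assay, not a number.
- compound 2 `COc1cc(-c2nnc3n2NC(c2ccco2)C(C(=O)c2ccc(C)cc2)S3)cc(OC)c1OC` gives > 100000 nM; again a limit.
- compound 3 `COc1cc(-c2nnc3n2NC(c2ccco2)C(C(=O)c2ccc(-c4ccccc4)cc2)S3)cc(OC)c1OC` gives > 100000 nM; again a limit.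

All three values in this assay sit at the limit of > 100000 nM in this assay, at which 3 of the 3 values shown sit, so compound 3 stands nowhere distinguishable from the others. The steps a step that the two limits leave unreadable from compound 1 to compound 2, a step that the two limits leave unreadable from compound 1 to compound 3 and a step that the two limits leave unreadable from compound 2 to compound 3 are unreadable; none of them can be sized.

Compound 4 `COc1cc(C(=O)C2Sc3nnc(-c4cc(OC)c(OC)c(OC)c4)n3NC2c2ccco2)cc(OC)c1OC` differs from compound 3 by 3,4,5-trimethoxyphenyl in place of 4-phenylphenyl on a carbonyl carbon. For the measured compounds named here, no measured step bears on this change in a readable way, and nothing among the values shown points toward a measurable number. The step that the limit leaves unreadable from compound 3 to compound 4 is expected to be none beyond the scatter, with the value most likely returned as a limit again. Compound 4 is thus expected to give 150000 nM in this assay, estimated between 50000 nM and 500000 nM.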

Compound 4, half-maximal inhibitory concentration: 48300 nM
For compound 4 the middle estimate is 3.1-fold (0.49 log units) above the measured one; the whole stated range lies above it.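

In this assay the group on the carbonyl carbon now registers: 3,4,5-trimethoxyphenyl gives an at least 2.0-fold lower number from compound 3 to compound 4 (0.31 log units; beyond the scatter), an at least 2.0-fold lower number from compound 2 to compound 4 (0.31 log units; beyond the scatter) and an at least 2.0-fold lower number from compound 1 to compound 4 (0.31 log units; beyond the scatter). The steps among 4-methoxyphenyl, 4-methylphenyl and 4-phenylphenyl cannot be read, and the three new steps are bounded on one side only. Only compound 4 returns a number rather than a limit: the limit of > 100000 nM in this assay, at which 3 of the 4 values shown sit.

Going by these compounds, whether this change depends on all three methoxy groups together or on fewer of them remains open. Also open, on these data alone, is what an amine or a carboxylic acid on this phenyl ring would give in this assay.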